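Cytotoxicity in the urea series: a chlorophenyl replacement

The source may report more compounds than this note shows. Statements on the series, on what has been measured and on what is new or still open speak of the compounds shown alone.

Three ureas on a shared core have been run in an ADME assay on BJ cells (Homo sapiens) for cytotoxicity, with a stated time of 72 h; on this read-out higher numbers stand for an effect only at larger amounts of compound and lower numbers for an effect already at smaller amounts. Compound 1 `Cc1cc(NC(=O)Nc2ncccc2C)c2ccccc2n1` reaches only the limit of the assay, > 25000 nM, so no number is known for it. Compound 2 `Cc1cc(NC(=O)Nc2cc(Cl)cc(Cl)c2)c2ccccc2n1` likewise stops at the limit, > 25000 nM. Going by the values given here, compound 3 `COC(=O)c1cccc(NC(=O)Nc2cc(C)nc3ccccc23)c1` is the one member with a number, giving 21000 nM in this assay. Among the compounds with values here, compound 1 therefore stands where most of the set stands, at the limit of > 25000 nM in this assay, at which 2 of the 3 values shown sit, and the single numerical value of compound 3 lies close to that limit.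

Compound 4 `Cc1cc(NC(=O)Nc2ccc(Cl)cc2)c2ccccc2n1` has not yet been measured in this assay. It differs from compound 1 by 4-chlorophenyl in place of 3-methylpyridin-2-yl on an amide-type nitrogen. Within the data shown here, no measured pair in the set differs in only one place, so no step is known to compare with. Given that compound 2, which also carries a chlorinated aryl group on the urea, sits at > 25000 nM, no step beyond the scatter is expected in this assay.

The expected step is a number no higher from compound 1 to compound 4 (the limit leaves the size open), that is, none beyond the scatter. Compound 4 is estimated at 25000 nM, with a range from 12000 nM to 50000 nM, and most likely reported as a limit.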

Compound 4, half-maximal effective concentration: > 25000 nM
Compound 4: no number, only a limit; the forecaster's own chance of this, stated with the estimate: 70%; the middle value lies on the limit itself.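

Compound 1 and compound 4 both end at a limit in this assay, so no step can be read for 4-chlorophenyl in place of 3-methylpyridin-2-yl on an amide-type nitrogen. The compounds shown leave open what number either compound would give, and whether this replacement changes the read-out at all.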